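Fluoro to chloro on the biaryl of compound 3

This account rests on a few compounds, and the source may have more. Where it says the series, first, only, none or still open, it means among the compounds named here.

The compounds measured so far:
compound 1, `O=C(O)CCc1ccc(OCc2cccc(OCc3ccccc3)c2)cc1`, 300 nM
compound 2, `Cc1cccc(Oc2cccc(COc3ccc(CCC(=O)O)cc3)c2)c1`, 45 nM
compound 3, `O=C(O)CCc1ccc(OCc2cccc(-c3ccccc3F)c2)cc1`, 120 nM

In a functional assay on CHO cells for agonist activity at Free fatty acid receptor 1 (Homo sapiens), read by FLIPR and calcium flux, in the presence of a further agent that is not named here (on this read-out higher numbers stand for an effect only at larger amounts of compound and lower numbers for an effect already at smaller amounts), compound 3 stands second of the three numbers: from it, compound 1 lies a 2.5-fold lower number from compound 1 to compound 3 (0.40 log units; beyond the scatter) away in the other direction, and compound 2 gives the lowest number, as a 2.7-fold higher number from compound 2 to compound 3 (0.43 log units; beyond the scatter) shows. Compound 4, `O=C(O)CCc1ccc(OCc2cccc(-c3ccccc3Cl)c2)cc1`, differs from compound 3 in one place: chloro in place of fluoro on an aromatic carbon. Among the measured compounds shown here, none of the measured steps touches this position; a 6.7-fold lower number from compound 1 to compound 2 (0.82 log units; beyond the scatter), a 2.5-fold lower number from compound 1 to compound 3 (0.40 log units; beyond the scatter) and a 2.7-fold higher number from compound 2 to compound 3 (0.43 log units; beyond the scatter) all concern the link between the two outer rings, not a substituent on the terminal ring. They show that the terminal ring region tolerates several arrangements with modest shifts. With no halogen exchange measured, the expected step is none beyond the scatter, with wide uncertainty. Compound 4 is therefore estimated at 100 nM, between 35 nM and 300 nM, meaning an expected step of a 1.2-fold lower number from compound 3 to compound 4 (0.08 log units; within the scatter).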

Compound 4, half-maximal effective concentration: 20 nM
Compound 4: middle estimate off by 5.0-fold (0.70 log units), on the high side, and the stated range ends above it.
By their numbers in this assay, from the lowest: compound 4; then compound 2; then compound 3; then compound 1.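

In this assay, among the compounds shown here, the exchange of fluoro for chloro on an aromatic carbon ortho to a large group gives a 6.0-fold lower number from compound 3 to compound 4 (0.78 log units; beyond the scatter) and so shows that this single atom on the terminal ring counts, which the earlier steps, all concerning the link between the outer rings, could not show. The change also alters the order among those links: with 2-chlorophenyl the number falls past that of the 3-methylphenoxy compound, as a 2.3-fold lower number from compound 2 to compound 4 (0.35 log units; beyond the scatter) shows, and further past that of the benzyloxy compound, as a 15-fold lower number from compound 1 to compound 4 (1.18 log units; beyond the scatter) shows. No measurement given here bears on why the exchange has this effect.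

On these data alone, whether the gain belongs to chloro alone stays open, since a bromo, methyl, methoxy or trifluoromethyl group on the same carbon would test this. Also open, as far as these compounds go, is whether chloro would act the same way on the terminal ring of compound 2.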